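The compounds below may be only part of what the source reports. "The series", "measured", "known", "first", "only" and "open" are said of these compounds alone.

For the measured compounds named here, compound 1, `CC(C)OC(=O)C1CN(C(=O)C2CCCCC2)CC(C)(C)c2cc(C#N)[nH]c21`, stands highest of the two values so far obtained in an assay on HEK293 cells for agonist activity at Bile acid receptor (Homo sapiens), read by a luciferase reporter (on this read-out lower numbers stand for smaller maximal responses and higher numbers for larger maximal responses), giving 127%. Compound 2, `CC(C)OC(=O)C1=CN(C(=O)c2cccc(C(F)(F)F)c2)CC(C)(C)c2cc(C#N)[nH]c21`, gives 94% in this assay, a gap to compound 1 that lies beyond the usual scatter; compound 2 differs from compound 1 in more than one place, so the two values alone do not isolate any single change. Compound 3, `CC(C)OC(=O)C1CN(C(=O)c2cccc(F)c2)CC(C)(C)c2cc(C#N)[nH]c21`, has not yet been measured. It differs from compound 1 in one place only: 3-fluorophenyl in place of cyclohexyl on a carbonyl carbon. Going by the values given here, no pair of measured compounds isolates this change. Compound 2, which also carries an aromatic ring on the carbonyl carbon, gives 94% in this assay. The expected step is therefore moderate and downward, a number 22 percentage points lower from compound 1 to compound 3 (beyond the scatter). Compound 3 is estimated at 105%, with a range from 80% to 130%.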

Compound 3, largest response reached (reported as efficacy), in percent of the reference or control that the assay uses: 84%
Compound 3: middle estimate off by 21 percentage points, on the high side; measured number inside the range.
By their numbers in this assay, from the lowest: compounds 3 and 2 (each within the scatter of the next); then compound 1.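

In this assay, the change on the carbonyl carbon bonded to the ring amide-type nitrogen can now be read on its own: 3-fluorophenyl in place of cyclohexyl gives a number 43 percentage points lower from compound 1 to compound 3 (beyond the scatter). The maximal response is thus sensitive to the group at this position, at least on the core of compound 1. No measurement of any property bears on this step, so the data offer no account of it.

From the compounds shown here alone, the change swaps a non-aromatic ring for an aromatic one and adds fluorine in a single step, so it remains open how much of the drop belongs to each; a plain phenyl group would separate the two. Going by these compounds, it is also open whether smaller or more open groups, such as cyclopentyl or a straight butyl chain, would keep the response of compound 1.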